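The source may hold more compounds than are shown below. What is called first, only, known or untested is meant among the compounds shown, and "the series" means these compounds.

The piece follows one change to compound 1, whose structure is `O[C@@H](c1ccccc1)[C@H]1CO[C@H](c2ccccc2)[C@@H](C/C=C/c2ccncc2)C1`. In a functional assay on HeLa cells (Homo sapiens) for cytotoxicity, read by WST assay, with a stated time of 48 h (a higher number here means a weaker inhibitor, a lower number a stronger inhibitor), compound 1 gives > 100000 nM, which is a limit of the assay rather than a number. Among the measured compounds shown here, the only other measured compound is compound 2, with the structure `COc1ccc([C@@H]2OC[C@H]([C@@H](O)c3ccc(OC)c(OC)c3)C[C@H]2C/C=C/c2ccc(OC)c(OC)c2)cc1`; in this assay compound 2 gives 29200 nM, a true number. For the measured compounds named here, these two differ in several places at once, so no single step between them can be read, and the evidence rests on one line: the limit of > 100000 nM in this assay, at which 1 of the 2 values shown sits.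

Compound 3 has the structure `O[C@@H](c1ccccc1)[C@H]1CO[C@H](c2ccccc2)[C@@H](C/C=C/C2CCCC2)C1`. It differs from compound 1 in one place: cyclopentyl in place of pyridin-4-yl on a double-bonded chain carbon bound to a double-bonded chain carbon. Going by the values given here, no measured pair shows what this change does, and nothing about the groups exchanged is known from the data.

Starting from a limit, the expectation is that compound 3 most likely also shows no measurable inhibition, with the step that the limit leaves unreadable from compound 1 to compound 3 in this assay expected to be no larger than the usual scatter. The estimate for compound 3 is 120000 nM, within a range from 40000 nM to 400000 nM.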

Compound 3, half-maximal inhibitory concentration: 9330 nM
Estimate against measurement, compound 3: 13-fold (1.11 log units) above; the whole stated range lies above it.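

In this assay compound 1 stands at > 100000 nM, which is a limit of the assay and not a number. Putting cyclopentyl in place of pyridin-4-yl on the chain gives an at least 10-fold lower number from compound 1 to compound 3 (1.03 log units; beyond the scatter) and so yields a true number within the range of the assay. This shows that the group at this place on the chain can change the read-out well beyond the scatter and that a ring of carbon only is tolerated there, although the full size of the step stays unknown, as it starts from a limit: the limit of > 100000 nM in this assay, at which 1 of the 3 values shown sits.

From the compounds shown here alone, with a single replacement at this place, it stays open whether the difference follows from the ring nitrogen, the aromatic ring or the ring size, as cyclopentyl differs from pyridin-4-yl in all three. Cyclohexyl, piperidin-4-yl or an open carbon chain such as pentyl at the same place would begin to separate these features.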